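This account rests on a few compounds, and the source may have more. Where it says the series, first, only, none or still open, it means among the compounds named here.

Measured so far:
- compound 1 `CC(CCNC(=O)c1c(Cl)cncc1Cl)N1CCC(C(Oc2cccc(C(=O)O)n2)c2ccc(C(F)(F)F)cc2)CC1`: 28700 nM
- compound 2 `CCO/N=C(/c1ccc(Br)cc1)C1CCN(C(C)CCNC(=O)c2c(C)cc[n+]([O-])c2C)CC1`: > 177000 nM
- compound 3 `CC(CCNC(=O)c1c(Cl)cncc1Cl)N1CCC(C(O)c2ccc(Br)cc2)CC1`: 198000 nM

In an ADME assay on PBMC cells (Homo sapiens) for cytotoxicity (a lower number here means that less compound is tolerated, a higher number that more compound is tolerated), compound 1 gives 28700 nM, the lowest of the two numbers in hand. Compound 3 gives 198000 nM, a gap beyond the scatter. For compound 2 the assay reports only a limit, > 177000 nM; this is the limit described as the limit of > 177000 nM in this assay, at which 1 of the 3 values shown sits.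

Compound 4 `CC(CCNC(=O)c1c(Cl)cncc1Cl)N1CCC(C(Oc2cc(Cl)ccn2)c2ccc(C(F)(F)F)cc2)CC1` is not yet measured in this assay. It differs from compound 1 in one place: 4-chloropyridin-2-yl in place of 6-carboxypyridin-2-yl on an oxygen on a saturated carbon. For the measured compounds named here, no measured pair shows this change, so its effect is unknown. A modest step downward, not far beyond the scatter, is expected: a 1.9-fold lower number from compound 1 to compound 4 (0.28 log units; within the scatter). Compound 4 is estimated at 15000 nM, within 4000 nM to 60000 nM.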

Compound 4, half-maximal cytotoxic concentration: 4260 nM
Beside the measured number, compound 4's estimate is 3.5-fold (0.55 log units) above it; the measured number falls inside the stated range.
By their numbers in this assay, from the lowest: compound 4; then compound 1; then compound 3.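

Exchanging 6-carboxypyridin-2-yl for 4-chloropyridin-2-yl on the oxygen gives, in this assay, a 6.7-fold lower number from compound 1 to compound 4 (0.83 log units; beyond the scatter). For the compounds shown here, the earlier compounds offered no step at all, so this is the first sign that this place alone can move the read-out beyond the scatter while the rest of the core stays fixed. Nothing measured here bears on why the number falls.

The change removes the carboxylic acid and adds the chlorine in one step, so their separate contributions remain unresolved. Also open, on these data alone, is how an amine or a methyl ester on this pyridine would read.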